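The source may report more compounds than this note shows. Statements on the series, on what has been measured and on what is new or still open speak of the compounds shown alone.

Compound 1 `Cc1nc(-c2cccnc2)sc1-c1nnc(-c2ccc(Br)cc2)o1` — in an ADME assay on PANC-1 cells (Homo sapiens) for cytotoxicity, read by MTT assay (on this read-out lower numbers stand for higher toxicity in this test and higher numbers for lower toxicity in this test), compound 1 gives > 100 ug/mL, a limit of the assay rather than a number.
Compound 2 `Cc1ccccc1-c1nnc(-c2sc(-c3cccnc3)nc2C)o1` — in this assay compound 2 gives > 100 ug/mL, again a limit.
Compound 3 `Cc1nc(-c2cccnc2)sc1-c1nnc(-c2ccccc2[N+](=O)[O-])o1` — in this assay compound 3 gives > 100 ug/mL, also a limit.

Compound 2 therefore stands at the same limit as the other two compounds; none of the three yields a number, and nothing ranks them. The unmeasured compound 4 `Cc1nc(-c2cccnc2)sc1-c1nnc(-c2ccc(O)cc2)o1` differs from compound 2 only by 4-hydroxyphenyl in place of 2-methylphenyl on an aromatic carbon. Among the compounds with values here, two measured steps touch the same position on the shared core: a step that the two limits leave unreadable from compound 1 to compound 2 and a step that the two limits leave unreadable from compound 2 to compound 3. Both are unreadable because of the limit of > 100 ug/mL in this assay, at which 3 of the 3 values shown sit. Neither a change of ring substituent pattern nor a swap from methyl to nitro moved any value off the limit, so no step beyond the scatter is expected for the step to compound 4, and the step that the limit leaves unreadable from compound 2 to compound 4 is estimated to be flat in this assay. Compound 4 is expected to give about 150 ug/mL, with a range from 70 ug/mL to 300 ug/mL, most likely reported again as a limit in this assay.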

Compound 4, half-maximal cytotoxic concentration: > 100 ug/mL
Compound 4: a limit, no number (the forecaster's own chance of this, stated with the estimate: 80%); the middle value does not contradict the limit.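

Within the data shown here, neither the step to compound 4 from compound 2 nor the one from compound 1 can be read, because all the values are limits: the limit of > 100 ug/mL in this assay, at which 4 of the 4 values shown sit.
The compounds shown leave open how they rank in this assay, and whether any group at this position would give a number.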